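The source may report more compounds than this note shows. Statements on the series, on what has been measured and on what is new or still open speak of the compounds shown alone.

Measured so far in a functional assay on HCT-116 cells (Homo sapiens) for inhibition, read by sulforhodamine B assay, with a stated time of 48 h, tested at 50 uM; a lower number here means less inhibition of growth, a higher number more inhibition of growth at the concentration tested 
Compound 1 `COc1ccc([C@@H]2C/C(=N/OCc3cn(-c4ccc(C#N)cc4)nn3)c3cc(CC=C(C)C)c(OC)cc3O2)cc1` gives 50% 
Compound 2 `CCCCOc1ccc([C@@H]2CC(=O)c3cc(CC=C(C)C)c(OC)cc3O2)cc1` gives 60% 

The values of compound 1 and compound 2 lie within the usual scatter of each other, so compound 2 cannot be told apart from compound 1 here. Compound 3 `COc1cc2c(cc1CC=C(C)C)C(=O)C[C@@H](c1ccc(Oc3ccc(Br)cc3)cc1)O2` has not yet been measured. It carries 4-bromophenyl in place of butyl on an oxygen on an aromatic ring, so butoxy becomes 4-bromophenoxy. For the measured compounds named here, compound 1 differs from compound 2 in more than one place, and no measured pair shows what this swap does. The estimated change in this assay is a number 5 percentage points lower from compound 2 to compound 3 (within the scatter) and is expected to stay within the scatter, in no firm direction. Compound 3 is estimated at 55% with an expected range from 35% to 75% in this test.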

Compound 3, percent growth inhibition at one concentration: 76%
Compound 3: the middle estimate sits 21 percentage points below what was measured, and the stated range ends below it.
By their numbers in this assay, from the lowest: compounds 1 and 2 (each within the scatter of the next); then compound 3.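

In this assay, for the compounds shown here, exchanging butoxy for 4-bromophenoxy gives a number 16 percentage points higher from compound 2 to compound 3 (beyond the scatter), the first step in this set that stands clear of the scatter. It shows that this place, on an oxygen on an aromatic ring, accepts more than a simple chain: a six-membered aromatic ring carrying bromine fits here without any loss of growth inhibition, and the reading improves modestly. Nothing available explains why this swap raises the number.

The compounds shown leave open whether the step goes with the ring or with the bromine, and a plain phenyl on the same oxygen would separate the two. Also open, on these data alone, is how a chain carrying an amine or a carboxylic acid on that oxygen would read in this assay.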